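Cytotoxicity of oxazole anilines: a nitrile to pyridinyloxy change

A few compounds are considered here, and "the series" means these few. Any claim that something is new, unique, unknown or untested is made for them only; others in the source may bear on it.

Measured so far:
compound 1, `CCc1cc(F)c(Cc2cnc(Nc3ccc(C#N)c(Cl)c3)o2)c(F)c1`: 10000 nM
compound 2, `N#Cc1ccc(Nc2ncc(Cc3c(F)cc(CC4CC4)cc3F)o2)cc1Cl`: 29000 nM

The study covers cytotoxicity in an ADME assay on MT2 cells (Homo sapiens) for inhibition; a higher number here means that more compound is tolerated, a lower number that less compound is tolerated. Among the measured compounds shown here, compound 1 gives 10000 nM in this assay, the lowest of the two numbers; its nearest neighbour is compound 2 at 29000 nM, and the only measured step, a 2.9-fold higher number from compound 1 to compound 2 (0.46 log units; beyond the scatter), concerns cyclopropyl in place of methyl on a saturated chain carbon bound to an aromatic carbon.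

Compound 3, `CCc1cc(F)c(Cc2cnc(Nc3ccc(Oc4cccnc4)c(Cl)c3)o2)c(F)c1`, has not been measured. It differs from compound 1 by (pyridin-3-yl)oxy in place of cyano on an aromatic carbon. For the measured compounds named here, no measured step touches this position or this kind of exchange, so the one known step gives no direct guide. With nothing to lean on, no step beyond the scatter is assumed in this assay, and the estimate for compound 3 is set near compound 1 with a wide range. Compound 3 is expected to give 10000 nM (range 3500 nM to 30000 nM). The expected step is therefore no change at the digits printed from compound 1 to compound 3 (within the scatter).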

Compound 3, half-maximal cytotoxic concentration: 5000 nM
For compound 3 the middle estimate is 2.0-fold (0.30 log units) above the measured one; the range from low to high includes it.
By their numbers in this assay, from the lowest: compounds 3 and 1 (each within the scatter of the next); then compound 2.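

In this assay the exchange of cyano for (pyridin-3-yl)oxy, on an aromatic carbon ortho to a chloro group, gives a 2.0-fold lower number from compound 1 to compound 3 (0.30 log units; within the scatter). This places a group of 7 heavy atoms with one six-membered aromatic ring where a group of 2 heavy atoms stood, with a step that stays within the scatter. Among the compounds shown here, the only earlier step, a 2.9-fold higher number from compound 1 to compound 2 (0.46 log units; beyond the scatter), left the nitrile in place, so this is the first reading at this position, and nothing at hand accounts for the result.

The compounds shown leave open whether the ring nitrogen or the oxygen link matters here, which a plain phenoxy group or an amine link could test. They also leave open whether the cyclopropyl for methyl step seen with the nitrile carries over to the (pyridin-3-yl)oxy series.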